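This account rests on a few compounds, and the source may have more. Where it says the series, first, only, none or still open, it means among the compounds named here.

The measured compounds:

Compound 1, `C=C1C[C@]23C[C@@]1(O)CC[C@H]2c1ccc(O)c(C)c1[C@@H]3Cn1cc(-c2ccccc2)nn1`: in a functional assay on SMMC-7721 cells (Homo sapiens) for cytotoxicity, read by MTT assay, with a stated time of 4 days (a lower number here means a stronger inhibitor, a higher number a weaker inhibitor), compound 1 gives > 20000 nM, which is a limit of the assay rather than a number.
Compound 2, `Cc1ccc(-c2cn(C[C@H]3c4c(ccc(O)c4C)[C@@H]4CC[C@@]5(C)C[C@]43CC5=O)nn2)cc1`: in this assay compound 2 gives > 20000 nM, again a limit of the assay.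
Compound 3, `Cc1ccc(-c2cn(C[C@H]3c4c(ccc(OS(=O)(=O)c5ccc(C)cc5)c4C)[C@@H]4CC[C@@]5(C)C[C@]43CC5=O)nn2)cc1`: in this assay compound 3 gives > 20000 nM, once more a limit of the assay.

Compound 2 and compound 3 differ in a single place, ((4-methylphenyl)sulfonyl in place of hydrogen on an oxygen on an aromatic ring). The step that the two limits leave unreadable from compound 2 to compound 3 cannot be sized because of the limit of > 20000 nM in this assay, at which 3 of the 3 values shown sit; nothing can be said of its direction either.

Compound 1 shares much of its framework with compound 2, but the difference between the two cores is not broken down here.

Compound 4, `C=C1C[C@]23C[C@@]1(O)CC[C@H]2c1ccc(OS(=O)(=O)c2ccc(C)cc2)c(C)c1[C@@H]3Cn1cc(-c2ccccc2)nn1`, has not yet been measured. It stands to compound 1 as compound 3 stands to compound 2: (4-methylphenyl)sulfonyl in place of hydrogen on an oxygen on an aromatic ring. The place at which the change is made is described in the same words for both pairs, so this is the same change, carried onto the core of compound 1.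

The expectation for compound 4 rests on two things: compound 1 itself sits at the limit of the assay with > 20000 nM, and the same change from compound 2 to compound 3 left the value at that limit. The step from compound 1 to compound 4 is therefore expected to be about a step that the limit leaves unreadable from compound 1 to compound 4, which is to say essentially no measurable movement. Compound 4 is estimated at 30000 nM, with a plausible range of 12000 nM to 80000 nM, and most likely the assay will again report only a limit.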

Compound 4, half-maximal inhibitory concentration: > 20000 nM
Compound 4 gave a limit, no number; the forecaster's own chance of this, stated with the estimate: 85%; the middle value lies beyond the limit too.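

In this assay compound 4 gives > 20000 nM, a limit of the assay and not a number. Compound 1 also sits at a limit, so the step to compound 4 cannot be read, in size or direction, because of this shared ceiling: the limit of > 20000 nM in this assay, at which 4 of the 4 values shown sit.

The compounds shown leave open whether (4-methylphenyl)sulfonyl in place of hydrogen on an oxygen on an aromatic ring shifts the value in this assay at all.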